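Swapping the aminophenoxy group for an acetylphenoxy group

The compounds below may be only part of what the source reports. "The series", "measured", "known", "first", "only" and "open" are said of these compounds alone.

Measured compounds:
compound 1 `CC(Nc1ccccc1Oc1ccccc1)=C1C(=O)CC(c2ccccc2)CC1=O`: 160 nM
compound 2 `CC(Nc1ccccc1Oc1cccc(F)c1)=C1C(=O)CC(c2ccccc2)CC1=O`: 360 nM
compound 3 `CC(Nc1ccccc1Oc1cccc(N)c1)=C1C(=O)CC(c2ccccc2)CC1=O`: 41 nM

In a functional assay on HMEC-1 cells (Homo sapiens) for antiproliferative activity, read by cell counting, with a stated time of 4 days (on this read-out lower numbers stand for stronger inhibition and higher numbers for weaker inhibition), compound 3 gives the lowest of the three numbers. It sits clear of compound 1, the nearest of the others, and further still from compound 2; both gaps are beyond the scatter. Compound 4 `CC(=O)c1ccc(Oc2ccccc2NC(C)=C2C(=O)CC(c3ccccc3)CC2=O)cc1` has not yet been measured in this assay. The change from compound 3 to compound 4 is 4-acetylphenyl in place of 3-aminophenyl on an oxygen on an aromatic ring.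

Among the compounds with values here, three measured steps bear on the outcome. Putting fluoro in place of hydrogen on an aromatic carbon gave a 2.3-fold higher number from compound 1 to compound 2 (0.35 log units; beyond the scatter). Putting amino in place of hydrogen on an aromatic carbon gave a 3.9-fold lower number from compound 1 to compound 3 (0.59 log units; beyond the scatter), and amino in place of fluoro gave an 8.8-fold lower number from compound 2 to compound 3 (0.94 log units; beyond the scatter). The amino group of compound 3 is thus tied to the best number seen, and compound 4 gives it up. Within the data shown here, no measured step covers the 4-acetylphenyl group, so its own contribution is unknown. The expected step is therefore a 4.9-fold higher number from compound 3 to compound 4 (0.69 log units; beyond the scatter), a weakening beyond the scatter, with wide uncertainty. Compound 4 is estimated at 200 nM, with a range from 60 nM to 700 nM.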

Compound 4, half-maximal inhibitory concentration: 180 nM
For compound 4 the middle estimate is 1.1-fold (0.05 log units) above the measured one; low and high end bracket the measured number.
By their numbers in this assay, from the lowest: compound 3; then compounds 1, 4 and 2 (each within the scatter of the next, the first and the last beyond it).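

In this assay the acetyl group does not move the number away from that of the bare ring, with acetyl in place of hydrogen giving a 1.1-fold higher number from compound 1 to compound 4 (0.05 log units; within the scatter) and the change from 3-fluorophenyl to 4-acetylphenyl giving a 2.0-fold lower number from compound 2 to compound 4 (0.30 log units; within the scatter) as well. This shows that a substituent on this ring need not raise the number as fluoro did, and that the larger 4-acetylphenyl group, with its carbonyl acceptor and no donor, sits on this oxygen without a step beyond the scatter against compound 1, while replacing 3-aminophenyl gives a 4.4-fold higher number from compound 3 to compound 4 (0.64 log units; beyond the scatter) and so leaves compound 3 alone with the lowest number of the four compounds. The data give no measured reason why the amino compound stands apart from the others.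

As far as these compounds go, the step from compound 3 to compound 4 changes both the group and its place on the ring, as the names 3-aminophenyl and 4-acetylphenyl show, so how much of it belongs to each stays open. Also open, from the compounds shown here alone, is whether a hydroxyl, a methylamino group or a carboxylic acid on this ring would give a number like that of compound 3 or like that of compound 1.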